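This account rests on a few compounds, and the source may have more. Where it says the series, first, only, none or still open, it means among the compounds named here.

Compounds measured in a functional assay on L1210 cells (Mus musculus) for antiproliferative activity, with a stated time of 48 h; on this read-out higher numbers stand for weaker inhibition and lower numbers for stronger inhibition:

Compound 1, `C=C(Br)C(=O)Nc1ccc(/C=C/C(=O)c2ccc(Cl)cc2)cc1`: 1100 nM
Compound 2, `C=C(Br)C(=O)Nc1ccc(/C=C/C(=O)c2cc(OC)c(OC)c(OC)c2)cc1`: 910 nM
Compound 3, `Nc1ccc(/C=C/C(=O)c2ccc(Cl)cc2)cc1`: 111000 nM

Compound 1 and compound 2 share the (1-bromoethenyl)carbonyl group on the aromatic nitrogen but carry different cores; the difference between the two cores is not broken down here. Their values in this assay lie within the usual scatter of each other, so nothing is said about which of the two is the stronger inhibitor.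

Compound 3 is the counterpart of compound 1 in which the change hydrogen in place of (1-bromoethenyl)carbonyl on a nitrogen on an aromatic ring has been made. Taking this step gives a 100-fold higher number from compound 1 to compound 3 (2.00 log units; beyond the scatter), a large loss of potency that far exceeds the scatter of the measurement.

Compound 4, `COc1cc(C(=O)/C=C/c2ccc(N)cc2)cc(OC)c1OC`, has not been measured. It stands to compound 2 exactly as compound 3 stands to compound 1: the change is hydrogen in place of (1-bromoethenyl)carbonyl on a nitrogen on an aromatic ring, the same change made on the same kind of position, and it occurs twice among the compounds shown. For the measured compounds named here, since the only precedent for this change is the pair of compound 1 and compound 3, the expectation for compound 4 rests on that single step. Compound 4 is therefore expected to lose potency by about the same amount, with a 99-fold higher number from compound 2 to compound 4 (2.00 log units; beyond the scatter), because the earlier change gave a 100-fold higher number from compound 1 to compound 3 (2.00 log units; beyond the scatter). Compound 4 is estimated to reach 90000 nM in this assay, with a plausible range from 30000 nM to 300000 nM.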

Compound 4, half-maximal inhibitory concentration: 14000 nM
For compound 4 the middle estimate is 6.4-fold (0.81 log units) above the measured one; the measured number lies below the stated range.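

Replacing (1-bromoethenyl)carbonyl with hydrogen on a nitrogen on an aromatic ring also weakens inhibition on the second core in this assay, with a 15-fold higher number from compound 2 to compound 4 (1.19 log units; beyond the scatter), so the direction of the step carries over from the core of compound 1 to the core of compound 2. The size of the step does not carry over, and the core therefore has to be taken into account when the change is moved within this series: the same change on two cores in this assay, a 100-fold higher number (2.00 log units; beyond the scatter) from compound 1 to compound 3 and a 15-fold higher number (1.19 log units; beyond the scatter) from compound 2 to compound 4, 6.6-fold (0.82 log units) apart, beyond the scatter of two such steps. Two cores show that the step is large on both but that its size can differ, and they show neither why it differs nor how large it would be on any further core.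

The compounds shown leave open which part of the (1-bromoethenyl)carbonyl group accounts for the step, as each compound carrying it is set only against its counterpart with the plain amino group. From the compounds shown here alone, what an acetyl group or a (1-chloroethenyl)carbonyl group on the same nitrogen would give in this assay remains open, as does the outcome of the same change on a core with other groups in place of the chlorine or the methoxy groups.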